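The compounds below may be only part of what the source reports. "The series", "measured", "known", "first", "only" and "open" are said of these compounds alone.

Of the compounds shown here, three of one shared core have been measured in a functional assay on HeLa cells (Homo sapiens) for antiproliferative activity, read by MTT assay, with a stated time of 48 h; on this read-out lower numbers stand for stronger inhibition and higher numbers for weaker inhibition. Compound 1 `Cc1cnc(Nc2ccc([N+](=O)[O-])cc2)nc1Nc1nc2ccccc2s1` gives 34300 nM in this assay. Compound 2 `Cc1cnc(Nc2ccc(S(N)(=O)=O)cc2)nc1Nc1nc2ccccc2s1` gives 2800 nM. Compound 3 `CS(=O)(=O)c1ccc(Nc2ncc(F)c(Nc3nc4ccc(F)cc4s3)n2)cc1`, which carries fluorine at two further places and a methylsulfonyl group, reaches only the limit > 50000 nM in this assay, so no number is known for it. Among the two numbers shown, compound 1 stands highest; its nearest neighbour is compound 2, and the step of a 12-fold lower number from compound 1 to compound 2 (1.09 log units; beyond the scatter) is a large one. Compound 4 `Cc1cnc(Nc2cccc(F)c2)nc1Nc1nc2ccccc2s1` is not yet measured. It differs from compound 1 in one place: 3-fluorophenyl in place of 4-nitrophenyl on a nitrogen on an aromatic ring. Among the measured compounds shown here, no measured step changes the same group in the same way, so the only guide is that the one measured change at this position, from compound 1 to compound 2, moved the number by a large amount, while compound 3 shows that other fluorine-bearing variants can sit at the limit (the limit of > 50000 nM in this assay, at which 1 of the 3 values shown sits). On this basis a step of about a 1.2-fold higher number from compound 1 to compound 4 (0.07 log units; within the scatter) is expected, with wide uncertainty. Compound 4 is therefore estimated at 40000 nM in this assay, within a range from 10000 nM to 150000 nM.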

Compound 4, half-maximal inhibitory concentration: 16300 nM
Compound 4: middle estimate off by 2.5-fold (0.39 log units), on the high side; the measured number falls inside the stated range.
By their numbers in this assay, from the lowest: compound 2; then compound 4; then compound 1. At a limit, above all of these: compound 3.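

In this assay the change from 4-nitrophenyl to 3-fluorophenyl brings a 2.1-fold lower number from compound 1 to compound 4 (0.32 log units; beyond the scatter) and so shows that the nitro group is not needed to reach this level of activity, even though the entering group counts no hydrogen-bond acceptors. The change at this position that gave the larger gain remains the one with the sulfamoyl group, which brings a 12-fold lower number from compound 1 to compound 2 (1.09 log units; beyond the scatter) and leaves compound 2 with the lowest number shown. Nothing shown here explains the size of either step.

The new step changes both the group and where it sits on the phenyl ring, so 4-fluorophenyl and 3-nitrophenyl would be needed to separate these two changes. As far as these compounds go, how an amine or a carboxylic acid on that phenyl ring would behave also remains open.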